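The compounds below may be only part of what the source reports. "The series", "measured", "known", "first", "only" and "open" are said of these compounds alone.

Measured compounds:
- compound 1 `CCOC(=O)c1c(C)[nH]c(=O)c(C#N)c1-c1ccccc1` in an ADME assay on MRC5 cells (Homo sapiens) for cytotoxicity, read by MTT assay, with a stated time of 24 h (on this read-out higher numbers stand for weaker inhibition and lower numbers for stronger inhibition), gives 220000 nM
- compound 2 `CCOC(=O)c1c(C)[nH]c(=O)c(C#N)c1-c1ccc([N+](=O)[O-])cc1` in this assay gives 2230000 nM

Going by the values given here, compound 2 stands at the higher of the two numbers: the step of a 10-fold higher number from compound 1 to compound 2 (1.01 log units; beyond the scatter) separates it from compound 1, the only other compound measured, and that step is larger than the scatter, so compound 2 is the weaker of the two in this assay and the weakest measured here.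

Compound 3 `CCOC(=O)c1c(C)[nH]c(=O)c(C#N)c1-c1ccc(C#N)cc1` has not yet been measured. It differs from compound 2 by cyano in place of nitro on an aromatic carbon. Among the compounds with values here, only one measured step bears on this change, namely a 10-fold higher number from compound 1 to compound 2 (1.01 log units; beyond the scatter); that step shows what the nitro group contributes against hydrogen on the same aromatic carbon, but no measured pair shows cyano against nitro or cyano against hydrogen. Because a 10-fold higher number from compound 1 to compound 2 (1.01 log units; beyond the scatter) was large, the group on that carbon matters in this assay, and the cyano group is expected to give a number between that of compound 1 and that of compound 2 rather than beyond either.

Compound 3 is therefore estimated at 900000 nM, within 250000 nM to 3000000 nM, an expected step of a 2.5-fold lower number from compound 2 to compound 3 (0.39 log units; beyond the scatter).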

Compound 3, half-maximal inhibitory concentration: 1220000 nM
Compound 3: the middle estimate sits 1.4-fold (0.13 log units) below what was measured; the range from low to high includes it.
By their numbers in this assay, from the lowest: compound 1; then compounds 3 and 2 (each within the scatter of the next).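

With cyano in place of nitro on this aromatic carbon, para to a large group, a 1.8-fold lower number from compound 2 to compound 3 (0.26 log units; within the scatter) in this assay, so the two groups cannot be told apart on this read-out. The earlier pair showed only that nitro differs from hydrogen at this position; now a 5.5-fold higher number from compound 1 to compound 3 (0.74 log units; beyond the scatter) shows that a second group, cyano, also separates from hydrogen by more than the scatter, although this step is only modest. Among these three compounds, then, the clear divide lies between compound 1, with hydrogen on this carbon, and compounds 2 and 3, each with a substituent there, and no compound goes against that pattern.

Going by these compounds, it remains open whether an amine, a methoxy group or a chlorine atom on the same carbon would fall with compound 1 or with compounds 2 and 3, and whether cyano or nitro would behave the same way on another carbon of that ring. Nothing presented here accounts for why the numbers fall as they do.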